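The compounds below may be only part of what the source reports. "The series", "measured", "known", "first", "only" and "open" are said of these compounds alone.

Measured compounds:
- compound 1, `Oc1cccc(-c2cc(-c3cccnc3)nc(-c3ccccc3Cl)c2)c1`, "not determined" (no result reported) in an ADME assay on HEK293 cells (Homo sapiens) for cytotoxicity, read by CCK-8 assay and cell counting, with a stated time of 2 days; on this read-out lower numbers stand for stronger inhibition and higher numbers for weaker inhibition
- compound 2, `Oc1cccc(-c2cc(-c3ccc(Cl)cc3)nc(-c3ccsc3)c2)c1`, 11200 nM in this assay
- compound 3, `Oc1cccc(-c2cc(-c3ccccn3)nc(-c3ccccc3Cl)c2)c1`, "not determined" (no result reported) in this assay

All three share a core carrying a 3-hydroxyphenyl group and differ in the two other aromatic groups attached to it. Only compound 2 has a number: in this assay compound 2 gives 11200 nM, which means that a rather high concentration is needed before the cells are harmed. Compound 3 stands without a single number; it is one of two entries, together with compound 1, for which no result is reported, so its cytotoxicity is simply unknown.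

Compound 4, `Oc1cccc(-c2cc(-c3ccsc3)nc(-c3ccccc3Cl)c2)c1`, is the next compound to be tested. It differs from compound 3 in one place: thiophen-3-yl in place of pyridin-2-yl on an aromatic carbon. Going by the values given here, since compound 3 has no value, there is no measured step to build on, and no pair among the measured compounds differs in exactly this way. Among the compounds with values here, the only anchor is compound 2, which also carries a thiophen-3-yl group and a chlorophenyl group on the same core and shows weak cytotoxicity.

Within the data shown here, compound 4 is therefore expected to land near 11000 nM, with a plausible range from 3000 nM to 40000 nM, resting on the single value of compound 2 at 11200 nM.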

Compound 4, half-maximal inhibitory concentration: 2720 nM
For compound 4 the middle estimate is 4.0-fold (0.61 log units) above the measured one; measured number below the stated range.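

Going by these compounds alone, the two compounds share the thiophen-3-yl group and differ only in the chlorophenyl group, which gives the first measured step in this small set. In this assay, 2-chlorophenyl in place of 4-chlorophenyl gives a 4.1-fold lower number from compound 2 to compound 4 (0.61 log units; beyond the scatter), so the place of the chlorine on this phenyl ring changes how much compound is needed to harm the cells, although the step is modest. Nothing measured here explains this shift.

The swap of pyridin-2-yl for thiophen-3-yl cannot be read, as compound 3 has no number, and compound 1 likewise gives no hint of how a pyridine ring behaves at this position. On these data alone, it also remains open whether the trend continues with 3-chlorophenyl, how an unsubstituted phenyl or a phenyl ring carrying a methoxy group or an amine would compare, and whether the same chlorine shift would have a similar effect with a group other than thiophen-3-yl on the core.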